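Working notes on a mirror-image pair in the series

The source may report more compounds than this note shows. Statements on the series, on what has been measured and on what is new or still open speak of the compounds shown alone.

Measured so far:
- compound 1 `O=C(NO)c1ccc(-c2cn([C@@H]3C[C@H](CO)N(Cc4ccccc4)C3)nn2)cc1`: 14%
- compound 2 `O=C(NO)c1ccc(-c2cn([C@H]3C[C@@H](CO)N(CCCc4ccccc4)C3)nn2)cc1`: < 10%

In an assay on Sf9 cells for inhibition of histone deacetylase 11 (Homo sapiens), read by fluorescence, tested at 0.5 uM (on this read-out higher numbers stand for more inhibition at the one concentration tested (going by the name of the read-out) and lower numbers for less inhibition), compound 1 gives 14%. Compound 2 returns only a limit of the assay, < 10%; one of the two values shown sits at this limit (the limit of < 10% in this assay, at which 1 of the 2 values shown sits). For the measured compounds named here, nothing connects compound 1 and compound 2 by a single change, so their two numbers are taken as they stand and no step between them is drawn.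

The next compound, compound 3 `O=C(NO)c1ccc(-c2cn([C@@H]3C[C@H](CO)N(CCCc4ccccc4)C3)nn2)cc1`, is the mirror image of compound 2: the two compounds have the same atoms and bonds and differ only in configuration as drawn: 2 of 2 stereo elements differ (all stereocentres are inverted: mirror images); a stereocentre at a saturated ring carbon is drawn S in compound 2 and R in compound 3; a stereocentre at a saturated ring carbon is drawn S in compound 2 and R in compound 3. Going by the values given here, no step between measured compounds is available in this assay for a change of this kind, so the size of the move has to be estimated from the standing of compound 2 alone. Since compound 2 sits at the limit, the expected step of a number at least 1 percentage points higher from compound 2 to compound 3 (that floor lies within the scatter) from inversion of both stereocentres is a small move, likely upward if any, and quite possibly none beyond the scatter. For compound 3 the expected inhibition in this assay is 11%, with a range of 0% to 26%, and a fair chance that only a limit is reported again.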

Compound 3, a percentage reported as inhibition, at one concentration (the size of the read-out at that concentration, not a potency): 15%
For compound 3 the middle estimate is 4 percentage points below the measured one; low and high end bracket the measured number.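

In this assay inversion of both stereocentres gives a number at least 5 percentage points higher from compound 2 to compound 3 (that floor lies within the scatter) and so supplies the first reading of configuration in this series, with nothing else separating the pair: the fact that compounds 2 and 3 differ only in the configuration as drawn

Compound 2 stands at a limit, so this step is a floor and not a measured size: the limit of < 10% in this assay, at which 1 of the 3 values shown sits.

With the configuration held, the chain change gives a number 1 percentage points higher from compound 1 to compound 3 (within the scatter) for phenethyl in place of phenyl on a saturated chain carbon bound to an amine nitrogen in a ring, so in this configuration the two chains are not told apart.

Still open, going by these compounds, is whether the two configurations truly differ beyond the scatter, since the floor of the step does not settle that. Also open, on these data alone, is how a longer chain in place of phenethyl, or a carboxylic acid at the end of that chain, would read in this assay and whether either would separate the mirror images any further.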